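This account rests on a few compounds, and the source may have more. Where it says the series, first, only, none or still open, it means among the compounds named here.

Of the compounds shown here, three have been measured in an assay for inhibition of 3-hydroxy-3-methylglutaryl-coenzyme A reductase (Rattus norvegicus); a lower number here means a stronger inhibitor, a higher number a weaker inhibitor. Compound 1 `Cc1cc(-c2cc(Cl)cc(C)c2/C=C/[C@@H]2C[C@@H](O)CC(=O)O2)ccc1F` gives 6 nM, compound 2 `O=C1C[C@H](O)CC(CCc2ccccc2-c2ccccc2)O1` gives 44000 nM, and compound 3 `COc1ccc(-c2cc(Cl)cc(Cl)c2/C=C/[C@@H]2C[C@@H](O)CC(=O)O2)cc1` gives 470 nM. Compound 3 therefore stands second highest of the three, far weaker than compound 1 and far stronger than compound 2, with both gaps beyond the scatter. Compound 4 `Cc1cc(C)cc(-c2cc(Cl)cc(Cl)c2/C=C/[C@@H]2C[C@@H](O)CC(=O)O2)c1` has not yet been measured; it differs from compound 3 by 3,5-dimethylphenyl in place of 4-methoxyphenyl on an aromatic carbon. For the measured compounds named here, no measured pair isolates this change, so its effect can only be guessed from compound 1, whose potency 6 nM shows that a ring with small carbon substituents is tolerated. A moderate step to a lower number in this assay is expected, a 3.1-fold lower number from compound 3 to compound 4 (0.50 log units; beyond the scatter). Compound 4 is estimated at 150 nM, within a range of 30 nM to 800 nM.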

Compound 4, half-maximal inhibitory concentration: 13 nM
For compound 4 the middle estimate is 12-fold (1.06 log units) above the measured one; measured number outside the range, below it.
By their numbers in this assay, from the lowest: compound 1; then compound 4; then compound 3; then compound 2.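

Swapping 4-methoxyphenyl for 3,5-dimethylphenyl on this aromatic carbon gives a 36-fold lower number from compound 3 to compound 4 (1.56 log units; beyond the scatter) in this assay and is the first change here isolated in one place. It shows that this group alone can shift the number greatly, although the two groups match in heavy-atom count and differ in that the entering one has no hydrogen-bond acceptor. No measurement here explains the size of this step. Still open, on these data alone, is whether both methyl groups are needed, since a phenyl with only one methyl remains unseen here. Also open, as far as these compounds go, is how an amine or a carboxylic acid on this ring would compare.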